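Chloro substitution on a shared thioacetamide quinazolinone scaffold

This account rests on a few compounds, and the source may have more. Where it says the series, first, only, none or still open, it means among the compounds named here.

Compound 1 `N#Cc1c(-c2ccccc2)nc(SCC(=O)Nn2c(COc3ccc(Cl)cc3Cl)nc3ccccc3c2=O)[nH]c1=O` and compound 2 `N#Cc1c(-c2ccc(Cl)cc2)nc(SCC(=O)Nn2c(COc3ccc(Cl)cc3Cl)nc3ccccc3c2=O)[nH]c1=O` share one core; in a functional assay on the whole organism (strain albino) for inhibition, with Rattus norvegicus as the target, read by paw edema, with stated times of 1 h and 3 h, at a dose of 100 mg/kg by the oral route (a lower number here means a weaker effect, a higher number a stronger effect of the compound at the dose given), compound 1 gives 86%, while compound 2 gives 64.9%. The change between them, (chloro in place of hydrogen on an aromatic carbon), produced a number 21.1 percentage points lower from compound 1 to compound 2 (beyond the scatter). Compound 3 `N#Cc1c(Nc2ccccc2)nc(SCC(=O)Nn2c(COc3ccc(Cl)cc3Cl)nc3ccccc3c2=O)nc1-c1ccc(O)cc1` carries a different core, and how it differs from compound 1 is not broken down here; in this assay compound 3 gives 91.2%. Compound 4 `N#Cc1c(Nc2ccc(Cl)cc2)nc(SCC(=O)Nn2c(COc3ccc(Cl)cc3Cl)nc3ccccc3c2=O)nc1-c1ccc(O)cc1` differs from compound 3 by chloro in place of hydrogen on an aromatic carbon, read one bond further out as anilino to (4-chlorophenyl)amino rather than phenyl to 4-chlorophenyl, so it is the same kind of change on a different part of the molecule. Because compound 1 to compound 2 showed a number 21.1 percentage points lower from compound 1 to compound 2 (beyond the scatter), the account expects a smaller but similar step, a number 15.2 percentage points lower from compound 3 to compound 4 (beyond the scatter), in this assay. Compound 4 is therefore estimated at 76%, between 58% and 90%.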

Compound 4, a percentage reported as inhibition, in the whole organism at one dose (the size of the read-out at that dose, not a potency): 79%
The estimate for compound 4 lay 3 percentage points below the measured number; measured number inside the range.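

In this assay, chloro in place of hydrogen gave a number 12.2 percentage points lower from compound 3 to compound 4 (beyond the scatter), the same direction as on the core of compound 1. The two steps can be read as one effect of this change: the same change on two cores in this assay, a number 21.1 percentage points lower (beyond the scatter) from compound 1 to compound 2 and a number 12.2 percentage points lower (beyond the scatter) from compound 3 to compound 4, 8.9 percentage points apart, within the scatter of two such steps. This shows that the drop carried from one core to the other in these two pairs at this single dose, with the chloro on a phenyl in one pair and on an anilino in the other, but two pairs establish no rule for other cores and give no reason for the drop.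

The compounds shown leave open whether fluoro, methoxy or a carboxylic acid at that same place would lower the number as chloro does. They also leave open how chloro would behave elsewhere on these rings.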